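Fluorophenyl Variant of a Weakly Active Ester Series

The compounds below may be only part of what the source reports. "The series", "measured", "known", "first", "only" and "open" are said of these compounds alone.

Three compounds built on a shared core are compared in a functional assay on MDA-MB-231 cells (Homo sapiens) for antiproliferative activity, read by MTT assay, with a stated time of 48 h; a lower number here means a stronger inhibitor, a higher number a weaker inhibitor. Compound 1 `C/C(=C\CC/C(C)=C/CC[C@@H]1[C@@]2(C)CCC(=O)C(C)(C)[C@H]2CC[C@@]1(C)O)CC/C=C(\C)C(=O)OCc1cn(-c2cccc(O)c2)nn1` carries a 3-hydroxyphenyl on an aromatic nitrogen and gives 139000 nM. Compound 2 `C/C(=C\CC/C(C)=C/CC[C@@H]1[C@@]2(C)CCC(=O)C(C)(C)[C@H]2CC[C@@]1(C)O)CC/C=C(\C)C(=O)OCc1cn(-c2ccccc2C(F)(F)F)nn1`, with 2-(trifluoromethyl)phenyl at that position, reaches only a limit of the assay, > 150000 nM. Compound 3 `C/C(=C\CC/C(C)=C/CC[C@@H]1[C@@]2(C)CCC(=O)C(C)(C)[C@H]2CC[C@@]1(C)O)CC/C=C(\C)C(=O)OCc1cn(C[C@@H]2O[C@H](n3ccc(=O)[nH]c3=O)[C@H]3OC(C)(C)O[C@H]32)nn1` likewise reaches only a limit, > 150000 nM. Within the data shown here, the one measured step, an at least 1.0-fold higher number from compound 1 to compound 2 (0.03 log units; that floor lies within the scatter), is small and is bounded by the limit of > 150000 nM in this assay, at which 2 of the 3 values shown sit, so compound 2 stands at the weak end of what this assay can report, without a number of its own. Compound 4 `C/C(=C\CC/C(C)=C/CC[C@@H]1[C@@]2(C)CCC(=O)C(C)(C)[C@H]2CC[C@@]1(C)O)CC/C=C(\C)C(=O)OCc1cn(-c2cccc(F)c2)nn1` differs from compound 2 in one place: 3-fluorophenyl in place of 2-(trifluoromethyl)phenyl on an aromatic nitrogen. Among the measured compounds shown here, no measured step covers a 3-fluorophenyl, and the only step bearing on this position lies within the scatter, so no change beyond the scatter is expected in this assay. Compound 4 is therefore estimated at 145000 nM, between 80000 nM and 300000 nM. The expected step of an at least 1.0-fold lower number from compound 2 to compound 4 (0.01 log units; that floor lies within the scatter) is thus essentially flat.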

Compound 4, half-maximal inhibitory concentration: 144000 nM
Beside the measured number, compound 4's estimate is 1.0-fold (0.00 log units) above it, and the stated range covers the measured number.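

Compound 4 gives this position a second true number, so a group on the aromatic nitrogen can now be compared by value with compound 1 and not only against a limit. In this assay, fluoro in place of hydroxy on the aromatic carbon gives a 1.0-fold higher number from compound 1 to compound 4 (0.02 log units; within the scatter), so this exchange shows no change that can be told apart from the scatter. The change from 2-(trifluoromethyl)phenyl to 3-fluorophenyl gives an at least 1.0-fold lower number from compound 2 to compound 4 (0.01 log units; that floor lies within the scatter), and this step rests on a limit, not on a number: the limit of > 150000 nM in this assay, at which 2 of the 4 values shown sit.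

All of the groups compared at this position leave the values within the scatter or at the limit. On these data alone, whether an amine or a carboxylic acid on the phenyl ring, or a longer alkyl chain in its place, would give a clearly lower number remains open.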